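The compounds below may be only part of what the source reports. "The series", "measured", "known", "first", "only" and "open" are said of these compounds alone.

Working notes on a cinnamamide series carrying the (3,5,6-trimethylpyrazin-2-yl)methoxy group, followed in a functional assay on SH-SY5Y cells (Homo sapiens) for cytotoxicity, read by MTT assay, with stated times of 24 h and 4 h; a higher number here means that more compound is needed for the effect, a lower number that less compound is needed.

Compound 1 `COc1cc(CNC(=O)/C=C/c2ccccc2)ccc1OCc1nc(C)c(C)nc1C` gives 7310 nM in this assay. Compound 2 `COc1cc(CNC(=O)/C=C/c2ccccc2OCc2nc(C)c(C)nc2C)ccc1OCc1nc(C)c(C)nc1C` gives 6280 nM in this assay. Compound 3 `COc1cc(CNC(=O)/C=C/c2ccc(OC)c(OCc3nc(C)c(C)nc3C)c2)ccc1O` gives 9250 nM in this assay. Compound 4 `COc1ccc(/C=C/C(=O)NCc2ccc(O)c(OC)c2)cc1` remains to be measured in this assay. The three measured values lie within the usual scatter of one another, so no ordering among compound 1, compound 2 and compound 3 can be read from them.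

One structural change recurs. Between compound 2 and compound 1 it is hydrogen in place of (3,5,6-trimethylpyrazin-2-yl)methoxy on an aromatic carbon, and it made a 1.2-fold higher number from compound 2 to compound 1 (0.07 log units; within the scatter). How the core of compound 2 differs from the core of compound 3 is not broken down here. Between compound 3 and compound 4 the change is hydrogen in place of (3,5,6-trimethylpyrazin-2-yl)methoxy on an aromatic carbon. The surroundings of the place are not the same: in compound 2 the leaving group sits ortho to a large group, whereas in compound 3 it sits ortho to a methoxy group and meta to a large group. The two changes are therefore the same kind of change, not the same change.

For this assay the step expected is a 1.1-fold higher number from compound 3 to compound 4 (0.06 log units; within the scatter), resting on the earlier 1.2-fold higher number from compound 2 to compound 1 (0.07 log units; within the scatter), which stayed within the scatter. For compound 4 the estimate is 10500 nM, with a range expected from 5000 nM to 25000 nM.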

Compound 4, half-maximal effective concentration: 11400 nM
Beside the measured number, compound 4's estimate is 1.1-fold (0.04 log units) below it; measured number inside the range.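

In this assay, hydrogen in place of (3,5,6-trimethylpyrazin-2-yl)methoxy on an aromatic carbon gives a 1.2-fold higher number from compound 3 to compound 4 (0.09 log units; within the scatter), and set beside the earlier case the two steps agree: the same change on two cores in this assay, a 1.2-fold higher number (0.07 log units; within the scatter) from compound 2 to compound 1 and a 1.2-fold higher number (0.09 log units; within the scatter) from compound 3 to compound 4, 1.1-fold (0.02 log units) apart, within the scatter of two such steps

On the two cores shown, then, the change carries over in the limited sense that it stays within the scatter on both, and the two steps cannot be told apart. This is agreement between two small steps and does not show that the group has any effect on the read-out on either core, nor does it show how the change would behave on a core other than these two.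

Going by these compounds, it remains open whether a different group at this place, such as an amine or a carboxylic acid, or a longer chain in place of the methylene link to the trimethylpyrazine, would give a step beyond the scatter in this assay. Also open is how the change reads in any measurement other than this assay, since the compounds shown here are followed in that one alone.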